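The source may report more compounds than this note shows. Statements on the series, on what has been measured and on what is new or still open speak of the compounds shown alone.

Compound 2 `Cn1c(=O)c(=O)n(C2CCCC2)c2nc(N/N=C/c3ccc(C(F)(F)F)cc3)ncc21` holds the highest of the two numbers given in a functional assay on HCT-116 cells (Homo sapiens) for antiproliferative activity, read by MTT assay (a higher number here means a weaker inhibitor, a lower number a stronger inhibitor), where compound 2 gives 29000 nM. Its nearest neighbour, compound 3 `Cn1c(=O)c(=O)n(C2CCCC2)c2nc(N/N=C/c3cccc([N+](=O)[O-])c3)ncc21`, gives 15200 nM in this assay, and the step of a 1.9-fold lower number from compound 2 to compound 3 (0.28 log units; within the scatter) stays within the scatter. Compound 1 `Cn1c(=O)c(=O)n(C2CCCC2)c2nc(N/N=C/c3ccccc3)ncc21` sits at the limit of > 100000 nM in this assay, at which 1 of the 3 values shown sits, recorded for compound 1 as > 100000 nM. From that limit the steps of an at least 3.4-fold lower number from compound 1 to compound 2 (0.53 log units; beyond the scatter) and an at least 6.5-fold lower number from compound 1 to compound 3 (0.81 log units; beyond the scatter) both reach beyond the scatter.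

The unmeasured compound 4 `Cn1c(=O)c(=O)n(C2CCCC2)c2nc(N/N=C/c3ccc(O)c(Br)c3)ncc21` differs from compound 2 by 3-bromo-4-hydroxyphenyl in place of 4-(trifluoromethyl)phenyl on a carbon with a double bond to nitrogen. Among the measured compounds shown here, only one measured step exchanges one substituted phenyl for another, a 1.9-fold lower number from compound 2 to compound 3 (0.28 log units; within the scatter), and it stays within the scatter. For the measured compounds named here, no measured step carries a hydroxy or a bromine, so the weight of the entering group rests on no measured comparison. Compound 4 is therefore expected to show a step of a 1.2-fold lower number from compound 2 to compound 4 (0.06 log units; within the scatter) in this assay. The estimate for compound 4 in this assay is 25000 nM, within a range from 7000 nM to 90000 nM.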

Compound 4, half-maximal inhibitory concentration: 17700 nM
Compound 4: the middle estimate sits 1.4-fold (0.15 log units) above what was measured, within the range that was stated.
By their numbers in this assay, from the lowest: compounds 3, 4 and 2 (each within the scatter of the next). At a limit, above all of these: compound 1.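

In this assay, among the compounds shown here, hydroxy and bromine appear at this position for the first time, yet a 1.6-fold lower number from compound 2 to compound 4 (0.21 log units; within the scatter) and a 1.2-fold higher number from compound 3 to compound 4 (0.07 log units; within the scatter) both stay within the scatter, so these three substituted phenyl groups cannot be told apart here, despite their different substituents. The step of an at least 5.6-fold lower number from compound 1 to compound 4 (0.75 log units; beyond the scatter) reaches beyond the scatter, so compound 4 joins the other two substituted phenyl compounds in separating from the unsubstituted phenyl. Compound 1 gives a limit, not a number: the limit of > 100000 nM in this assay, at which 1 of the 4 values shown sits.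

Hydroxy and bromine enter together in compound 4, and neither is seen alone, so their separate contributions remain open. As far as these compounds go, it also remains open how an amine or a carboxylic acid on the phenyl ring, or a longer chain in place of the ring, would read in this assay.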